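Cyclohexylmethyl Ether Variant of an Aryl Ether Series

The source may report more compounds than this note shows. Statements on the series, on what has been measured and on what is new or still open speak of the compounds shown alone.

Compound 1 `CCC(C)Oc1ccc(C(O)C2OC(=O)c3c(OC)cc(OC)cc32)cc1` gives > 40000 nM in an ADME assay on RAW264.7 cells (Mus musculus) for cytotoxicity, read by MTT assay, with a stated time of 24 h, in the presence of a further agent that is not named here (a higher number here means a weaker inhibitor, a lower number a stronger inhibitor), which is a limit of the assay.
Compound 2 `COc1cc(OC)c2c(c1)C(C(O)c1ccc(OCCOc3ccccc3)cc1)OC2=O` gives > 40000 nM in this assay, a limit of the assay.
Compound 3 `COc1cc(OC)c2c(c1)C(C(O)c1ccc(OCc3ccccc3)cc1)OC2=O` gives > 40000 nM in this assay, a limit of the assay.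

Compound 1 therefore stands only at a limit in this assay, and so do its two neighbours, because of the limit of > 40000 nM in this assay, at which 3 of the 3 values shown sit. The steps a step that the two limits leave unreadable from compound 1 to compound 2 and a step that the two limits leave unreadable from compound 1 to compound 3, both exchanges of the group on the same oxygen, stay unreadable between two limits, as does a step that the two limits leave unreadable from compound 2 to compound 3. Compound 4 `COc1cc(OC)c2c(c1)C(C(O)c1ccc(OCC3CCCCC3)cc1)OC2=O` carries cyclohexylmethyl in place of sec-butyl on an oxygen on an aromatic ring. Three limits and no readable step leave no direction beyond the scatter to expect. Compound 4 is estimated at 45000 nM, in a range from 20000 nM to 100000 nM, most probably reported again only as a limit. The expected step that the limit leaves unreadable from compound 1 to compound 4 is accordingly none beyond the scatter.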

Compound 4, half-maximal inhibitory concentration: > 40000 nM
Compound 4 was reported as a limit (the forecaster's own chance of this, stated with the estimate: 85%); the middle value does not contradict the limit.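

Compound 4 sits at a limit in this assay, as do compounds 1, 2 and 3, so no step between them can be read: the limit of > 40000 nM in this assay, at which 4 of the 4 values shown sit.

The compounds shown leave open whether the group on that oxygen changes the read-out at all.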